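Removing One Hydroxy Group from a Poorly Soluble Amide

A few compounds are considered here, and "the series" means these few. Any claim that something is new, unique, unknown or untested is made for them only; others in the source may bear on it.

Measured so far in a physicochemical assay for solubility, read by spectrophotometry, in phosphate buffer, measured as kinetic solubility, with a stated time of 18 h, at pH 7.4 (a higher number here means a more soluble compound, a lower number a less soluble compound), are two compounds:
- compound 1 `O=C(O)COc1cc(Cl)c(C(=O)Nc2cccc(-c3nc4ccccc4s3)c2)cc1[N+](=O)[O-]` gives 6700 nM
- compound 2 `O=C(Nc1ccc(O)c(-c2nc3ccccc3s2)c1)c1cc([N+](=O)[O-])ccc1Cl` gives 23 nM

Compound 2 holds the lower of the two numbers (23 nM), and compound 1 (6700 nM) stands above it by a gap beyond the scatter. Compound 3 `O=C(Nc1cccc(-c2nc3ccccc3s2)c1)c1cc([N+](=O)[O-])ccc1Cl` differs from compound 2 by one change: hydrogen in place of hydroxy on an aromatic carbon, ortho to a 1,3-benzothiazol-2-yl group (hydrogen in place of hydroxy on an aromatic carbon). Going by the values given here, no two measured compounds differ in one place only, so the data do not show how large such a change tends to be. The expectation in this assay is therefore no step beyond the scatter, in either direction. The estimate is a 1.3-fold higher number from compound 2 to compound 3 (0.12 log units; within the scatter) for this step. Compound 3 is expected at 30 nM (estimated range 8 nM to 150 nM).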

Compound 3, solubility: 580 nM
The estimate for compound 3 lay 19-fold (1.29 log units) below the measured number; measured number above the stated range.
By their numbers in this assay, from the lowest: compound 2; then compound 3; then compound 1.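

In this assay the exchange of hydroxy for hydrogen on this aromatic carbon, ortho to a 1,3-benzothiazol-2-yl group and para to a large group, gives a 25-fold higher number from compound 2 to compound 3 (1.40 log units; beyond the scatter) and shows that this one position can move the read-out well beyond the scatter. Hydrogen in place of carboxymethoxy on an aromatic carbon gives a 12-fold lower number from compound 1 to compound 3 (1.06 log units; beyond the scatter) in this assay and is likewise a large step, so compound 3 stands between the other two compounds.

From the compounds shown here alone, how a methoxy group, an amine or a carboxylic acid on this same carbon would compare with hydroxy and hydrogen remains open. Also open, going by these compounds, is whether the hydroxy step would keep its size on a core carrying carboxymethoxy.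

No supporting measurement shown here bears on the reason for either step.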